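This account rests on a few compounds, and the source may have more. Where it says the series, first, only, none or still open, it means among the compounds named here.

The measurements, all in an assay for inhibition of mitogen-activated protein kinase kinase kinase 14 (Homo sapiens), read by luminescence and ADP-Glo, with a stated time of 120 min, in the presence of a further agent that is not named here (a lower number here means a stronger inhibitor, a higher number a weaker inhibitor), are these:

Compound 1 `CC(O)(C#Cc1ccc(N2CCCC2)c(Nc2ncnc3[nH]ccc23)c1)c1nccs1`: 107 nM
Compound 2 `C[C@H]1CN(c2ccc(C#CC(C)(O)c3nccs3)cc2Nc2ncnc3[nH]ccc23)CCN1`: 69.2 nM
Compound 3 `CC(O)(C#Cc1ccc(N2CC3CC2CN3)c(Nc2ncnc3[nH]ccc23)c1)c1nccs1`: 200 nM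

Within the data shown here, compound 3 has the highest of the three numbers; its gap to compound 1 lies within the scatter, and only the step of a 2.9-fold higher number from compound 2 to compound 3 (0.46 log units; beyond the scatter) is beyond it. Compound 4 `CN1CCN(c2ccc(C#CC(C)(O)c3nccs3)cc2Nc2ncnc3[nH]ccc23)CC1` carries the change (a group of 7 heavy atoms (5 carbon, 2 nitrogen; one six-membered non-aromatic ring with 2 hetero atoms) in place of a group of 7 heavy atoms (5 carbon, 2 nitrogen; 2 five-membered non-aromatic rings with 1 hetero atom each), on an aromatic carbon). Among the measured compounds shown here, the closest measured step is the one from compound 2 to compound 3, which runs the opposite way between a six-membered ring with two hetero atoms and the bicyclic group; the steps of a 1.5-fold lower number from compound 1 to compound 2 (0.19 log units; within the scatter) and a 1.9-fold higher number from compound 1 to compound 3 (0.27 log units; within the scatter) both stayed within the scatter. A modest drop in this assay is therefore expected for compound 4, about a 2.5-fold lower number from compound 3 to compound 4 (0.40 log units; beyond the scatter), giving an estimated 80 nM with a range of 35 nM to 200 nM.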

Compound 4, half-maximal inhibitory concentration: 78.3 nM
For compound 4 the middle estimate is 1.0-fold (0.01 log units) above the measured one, within the range that was stated.
By their numbers in this assay, from the lowest: compounds 2, 4, 1 and 3 (each within the scatter of the next, the first and the last beyond it).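

At this position, on the aromatic carbon para to the 3-hydroxy-3-(1,3-thiazol-2-yl)but-1-yn-1-yl group, 4-methylpiperazin-1-yl in place of the bicyclic group gives a 2.6-fold lower number from compound 3 to compound 4 (0.41 log units; beyond the scatter), matching in size the earlier step between compound 2 and compound 3. Moving the methyl from 3-methylpiperazin-1-yl to 4-methylpiperazin-1-yl gives a 1.1-fold higher number from compound 2 to compound 4 (0.05 log units; within the scatter), and 4-methylpiperazin-1-yl in place of pyrrolidin-1-yl gives a 1.4-fold lower number from compound 1 to compound 4 (0.14 log units; within the scatter), so only the bicyclic group stands apart. Nothing shown explains these differences.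

On these data alone, whether morpholine, piperidine or an open dimethylamino group would fit this position remains open.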